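The compounds below may be only part of what the source reports. "The series", "measured", "known", "first", "only" and "open" are said of these compounds alone.

Compound 1 `C=C[C@@](C)(/C=C/c1ccc(Nc2ccccc2)cc1)CCC=C(C)C` gives in an ADME assay on BJ cells (Homo sapiens) for cytotoxicity, with a stated time of 72 h (a lower number here means that less compound is needed, a higher number that more compound is needed for the effect), only a limit, > 36600 nM. Compound 2 `C=C[C@@](C)(/C=C/c1ccc(Nc2cc(F)c(F)c(F)c2)cc1)CCC=C(C)C` also reaches only a limit in this assay, > 36600 nM. Compound 3 `C=C[C@@](C)(/C=C/c1ccc(Nc2cccc(C(F)(F)F)c2)cc1)CCC=C(C)C` likewise returns only a limit in this assay, > 36600 nM. The two steps taken from compound 1, a step that the two limits leave unreadable from compound 1 to compound 2 and a step that the two limits leave unreadable from compound 1 to compound 3, therefore carry no readable size, as the limit of > 36600 nM in this assay, at which 3 of the 3 values shown sit, shows. Compound 4 `C=C[C@@](C)(/C=C/c1ccc(-c2ccc(F)cc2)cc1)CCC=C(C)C` differs from compound 1 by 4-fluorophenyl in place of anilino on an aromatic carbon. Going by the values given here, no measured step covers this change, and none of the three values offers a number to move from, so the only anchor is the limit itself. Compound 4 is expected to sit at that same limit in this assay, estimated at 40000 nM within 15000 nM to 120000 nM. The expected step that the limit leaves unreadable from compound 1 to compound 4 is accordingly none beyond the scatter.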

Compound 4, half-maximal effective concentration: > 36600 nM
Compound 4: only a limit was reported (the forecaster's own chance of this, stated with the estimate: 85%); the middle value lies beyond the limit too.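

The step between compound 1 and compound 4 cannot be read, as both values are limits: the limit of > 36600 nM in this assay, at which 4 of the 4 values shown sit.

The compounds shown leave open whether any of these changes to the shared core has an effect in this assay.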